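Aryl swap on the triazole arm of compound 2

A few compounds are considered here, and "the series" means these few. Any claim that something is new, unique, unknown or untested is made for them only; others in the source may bear on it.

Measured so far:
compound 1 `C=C1C[C@]23C[C@@]1(O)CC[C@H]2c1ccc(O)c(C)c1[C@@H]3Cn1cc(-c2ccc(OC)cc2)nn1` — > 20000 nM in a functional assay on SW480 cells (Homo sapiens) for cytotoxicity, read by MTT assay, with a stated time of 4 days; a lower number here means a stronger inhibitor, a higher number a weaker inhibitor
compound 2 `Cc1ccc(S(=O)(=O)Oc2ccc3c(c2C)[C@H](Cn2cc(-c4ccc(C(F)(F)F)cc4)nn2)[C@@]24CC(=O)[C@@](C)(CC[C@@H]32)C4)cc1` — > 20000 nM in this assay
compound 3 `C=C1C[C@]23C[C@@]1(O)CC[C@@H]2c1cccc(C)c1[C@@H]3Cn1cc(-c2ccc(OC)cc2)nn1` — > 20000 nM in this assay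

Each of these three values is a limit of the assay and not a measured number. In this assay compound 1 reaches only its limit. Compound 2 likewise returns only a limit. Compound 3 returns only a limit as well. For the measured compounds named here, compound 2 therefore stands where the whole set stands, at the limit of > 20000 nM in this assay, at which 3 of the 3 values shown sit; no compound is separated from any other, and no step between measured compounds can be stated. Nothing here shows which part of the shared core, if any, carries cytotoxic activity.

Compound 4 `Cc1ccc(S(=O)(=O)Oc2ccc3c(c2C)[C@H](Cn2cc(-c4ccccn4)nn2)[C@@]24CC(=O)[C@@](C)(CC[C@@H]32)C4)cc1` differs from compound 2 in one place: pyridin-2-yl in place of 4-(trifluoromethyl)phenyl on an aromatic carbon. Going by the values given here, no measured step bears on this kind of change, and the three limits give no direction to read from. The step of a number no higher from compound 2 to compound 4 (the limit leaves the size open) is expected to be none beyond the scatter, with another limit the most probable outcome. For compound 4 the estimate is 20000 nM, with a range from 6000 nM to 60000 nM, and a real number below the limit is expected only as the less likely case.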

Compound 4, half-maximal inhibitory concentration: > 20000 nM
Compound 4 ended at the assay's limit; the forecaster's own chance of this, stated with the estimate: 75%; the middle value lies on the limit itself.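

Compound 4 returns only a limit in this assay, > 20000 nM. Compound 2 also sits at a limit, so no step can be read between compound 2 and compound 4. Open still is whether pyridin-2-yl, 4-(trifluoromethyl)phenyl or any part of the shared core carries cytotoxic activity in this assay.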